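The source may hold more compounds than are shown below. What is called first, only, known or untested is meant among the compounds shown, and "the series" means these compounds.

Measured compounds:
- compound 1 `CCCCCCCCCCCCCCC(N)CO`: in an ADME assay on cells (Splenocyte, Mus musculus, strain BALB/c) for cytotoxicity, read by MTT assay, tested at 1 ug/mL (on this read-out lower numbers stand for a weaker effect and higher numbers for a stronger effect at the one concentration tested), compound 1 gives 15.1%
- compound 2 `CCCCCCCCCCCCCCC(CO)NC(=O)CCCC(=O)O`: in this assay compound 2 gives "not determined" (no result reported)

Within the data shown here, compound 1 is the only compound with a number on this read-out, so it has no neighbour to be ranked against; on its own, the figure for compound 1 sits in the low part of the percentage scale, meaning a weak effect at the single concentration tested. Compound 2 carries no number and therefore adds nothing about how far a structural change can move the read-out here.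

The step to compound 3 `CCCCCCCCCCCCCCC(CO)N(CC)CC` changes one place in compound 1: diethylamino in place of amino on a saturated chain carbon bound to two saturated chain carbons. Among the measured compounds shown here, no pair of measured compounds shows a step of any kind in this assay, so there is no measured yardstick for this change. The expectation is a step from compound 1 to compound 3 that is small, upward at most, and quite possibly within the ordinary scatter. Compound 3 is therefore estimated at 20%, within 6% to 42%, an expected step of a number 4.9 percentage points higher from compound 1 to compound 3 (within the scatter).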

Compound 3, a percentage reported as activity, at one concentration (the size of the read-out at that concentration, not a potency): 7.5%
Compound 3: middle estimate off by 12.5 percentage points, on the high side; the range from low to high includes it.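

In this assay, among these compounds, putting diethylamino in place of amino on a saturated chain carbon bound to two saturated chain carbons gives a number 7.6 percentage points lower from compound 1 to compound 3 (within the scatter), the first step that can be read at this position. The entering group has 5 heavy atoms against 1 for the group that leaves, and it has 0 hydrogen-bond donors against 1, yet this exchange does not move the read-out beyond what repeated measurements would be expected to scatter, so this single step gives no sign that the change matters in this assay. Nothing available here offers an explanation for this result.

A single step at one concentration cannot show whether other groups at this position, such as dimethylamino, an acetamide or a carboxylic acid joined directly to the chain, would stay as close to compound 1 as compound 3 does. It also leaves open whether a longer or shorter chain would shift the read-out more than this change at the amino group does.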